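The compounds below may be only part of what the source reports. "The series", "measured", "known", "first", "only" and "open" are said of these compounds alone.

Measured so far:
compound 1 `C(=N/Nc1nc(-c2ccccc2)cs1)\c1ccc(-n2ccnc2)cc1`: 21.8%
compound 2 `C(=N/Nc1nc(-c2ccccc2)cs1)\c1ccc(-n2cncn2)cc1`: 28.4%

In an ADME assay on THP-1 cells (Homo sapiens) for cytotoxicity, read by MTT assay, tested at 50 ug/mL (on this read-out higher numbers stand for more inhibition at the one concentration tested (going by the name of the read-out) and lower numbers for less inhibition), compound 1 gives 21.8% and compound 2 gives 28.4%. Within the data shown here, the single measured step, a number 6.6 percentage points higher from compound 1 to compound 2 (within the scatter), is within the scatter, so the two numbers cannot be told apart; compound 2 has the larger of the two figures but only by an amount that repeated measurements would blur.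

Compound 3 `Clc1ccc(-c2csc(N/N=C/c3ccc(-n4cncn4)cc3)n2)c(Cl)c1` has not been measured. It differs from compound 2 in one place: 2,4-dichlorophenyl in place of phenyl on an aromatic carbon. Among the measured compounds shown here, no measured step touches this part of the shared core; the only step known concerns the other end of the molecule, so there is no direct guide to what the change does. The expectation is therefore a number near that of compound 2, with a wide range. For compound 3 the estimate is 35% (range 15% to 60%), an expected step of a number 6.6 percentage points higher from compound 2 to compound 3 (within the scatter).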

Compound 3, a percentage reported as inhibition, at one concentration (the size of the read-out at that concentration, not a potency): 8.9%
Beside the measured number, compound 3's estimate is 26.1 percentage points above it, and the stated range ends above it.
By their numbers in this assay, from the lowest: compound 3; then compounds 1 and 2 (each within the scatter of the next).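

In this assay, 2,4-dichlorophenyl in place of phenyl gives a number 19.5 percentage points lower from compound 2 to compound 3 (beyond the scatter), the only step among these compounds that lies beyond the scatter. This shows that the aromatic carbon next to the ring nitrogen is a place where a change can move the inhibition seen at the one concentration tested, whereas the triazole-for-imidazole swap at the other end of the molecule, a number 6.6 percentage points higher from compound 1 to compound 2 (within the scatter), cannot be told from noise. Nothing available explains why this replacement gives the lower number.

From the compounds shown here alone, the change brings in two chlorine atoms at once, so it remains open whether a phenyl with a single chlorine would give a similar number. Going by these compounds, how a phenyl carrying a methoxy group or an amine would read at this place also remains open.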